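Sulfoxide chain lengthening on the shared triazole core

The source may hold more compounds than are shown below. What is called first, only, known or untested is meant among the compounds shown, and "the series" means these compounds.

Compound 1 `CSc1n[nH]c(-c2ccc(F)cc2)n1` returns only a limit in a functional assay on the whole organism for antagonist activity, with Mus musculus as the target (on this read-out lower numbers stand for an effect already at smaller amounts and higher numbers for an effect only at larger amounts of compound), namely > 200 mg/kg. Going by the values given here, compound 2 `Cn1c(-c2ccccc2)nnc1[S+](C)[O-]` holds the sole number in this assay: compound 2 gives 18.6 mg/kg. The other value is the limit of > 200 mg/kg in this assay, at which 1 of the 2 values shown sits, and marks no number. Compound 3 `CC[S+]([O-])c1nnc(-c2ccccc2)n1C` differs from compound 2 by methyl in place of hydrogen on a saturated chain carbon bound to a sulfur. Among the compounds with values here, no measured step of this kind exists, so a change of this size is expected to stay within the scatter, with no clear direction. Compound 3 is therefore expected near 20 mg/kg in this assay, estimated between 8 mg/kg and 50 mg/kg. The step of a 1.1-fold higher number from compound 2 to compound 3 (0.03 log units; within the scatter) is expected to be small.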

Compound 3, dose for half-maximal effect: 14.4 mg/kg
The estimate for compound 3 lay 1.4-fold (0.14 log units) above the measured number; the measured number falls inside the stated range.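

Going by these compounds alone, this is the first measured step at this position. In this assay, methyl to ethyl on the saturated chain carbon bound to a sulfur gives a 1.3-fold lower number from compound 2 to compound 3 (0.11 log units; within the scatter), so this one-carbon extension leaves the read-out unresolved from that of the parent compound. No measured property on hand bears on this step.

Going by these compounds, whether a propyl chain, a branched isopropyl group or a benzyl group at this place would keep the number within the scatter stays open. So does the effect of a terminal amine or carboxylic acid on the chain.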